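Replacing a Bromine by an Amide on the Fused Ring

This account rests on a few compounds, and the source may have more. Where it says the series, first, only, none or still open, it means among the compounds named here.

Compound 1 `Cn1ccnc1C(CC(=O)O)c1ccc(OCC2COc3ccc(Cl)cc3O2)cc1`: 5880 nM
Compound 2 `Cn1cncc1C(CC(=O)O)c1ccc(OCC2COc3ccc(Cl)cc3O2)cc1`: 3060 nM
Compound 3 `CC#C[C@@H](CC(=O)O)c1ccc(OC[C@H]2COc3ccc(Br)cc3O2)cc1`: 210 nM

In a functional assay on HEK293 cells for agonist activity at Free fatty acid receptor 1 (Homo sapiens), read by fluorescence and calcium flux, with a stated time of 10 min (a higher number here means that more compound is needed for the effect, a lower number that less compound is needed), compound 3 gives the lowest number of the three measured compounds; compound 2 gives 3060 nM and compound 1 gives 5880 nM, both beyond the scatter from compound 3. Compound 4 `CC#C[C@@H](CC(=O)O)c1ccc(OC[C@H]2COc3ccc(C(=O)N(C)C)cc3O2)cc1` shares the alkyne-bearing core of compound 3 and differs only on the fused ring system: dimethylcarbamoyl in place of bromo on an aromatic carbon.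

Among the compounds with values here, the single measured step, a 1.9-fold lower number from compound 1 to compound 2 (0.28 log units; within the scatter), concerns a swap of imidazole rings on the saturated chain carbon and says nothing about the fused ring. Within the data shown here, no measured pair compares bromo with dimethylcarbamoyl, so the direction of the change from compound 3 to compound 4 cannot be read from the data. A halogen is replaced by a larger group with one hydrogen-bond acceptor, and in the absence of a comparable step the expectation is a moderate rise in the number, with wide uncertainty in both directions.

Compound 4 is therefore expected to give about 500 nM in this assay, with a range from 120 nM to 2000 nM, which would mean an estimated step of a 2.4-fold higher number from compound 3 to compound 4 (0.38 log units; beyond the scatter).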

Compound 4, half-maximal effective concentration: > 30000 nM
Compound 4 ended at the assay's limit; the forecaster's own chance of this, stated with the estimate: 5%; middle value at least 60-fold (1.77 log units) from the limit.
By their numbers in this assay, from the lowest: compound 3; then compounds 2 and 1 (each within the scatter of the next). At a limit, above all of these: compound 4.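

In this assay compound 4 gives > 30000 nM, which is a limit of the assay and not a number, so it marks only where the readings stop: the limit of > 30000 nM in this assay, at which 1 of the 4 values shown sits.

Within the data shown here, on the aromatic carbon of the fused system, dimethylcarbamoyl in place of bromo gives an at least 140-fold higher number from compound 3 to compound 4 (2.15 log units; beyond the scatter), the first measured change at this position, since the only earlier step was an imidazole swap on the saturated chain carbon. That earlier step lay within the scatter, whereas this one shows that the number in this assay can depend very strongly on the group at this place on the fused ring, though this rests on a single pair of compounds.

The pair cannot separate the effect of the larger group, five heavy atoms against one, from that of the amide carbonyl, and the limit leaves the true size of the step unknown. From the compounds shown here alone, a methoxy, a nitrile, a primary amide or a small amine at this position could help to tell these apart, and whether any group other than a halogen is accepted here stays open.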